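A Hydroxyethyl Tail Replaces the Amide on the Aryl Arm

A few compounds are considered here, and "the series" means these few. Any claim that something is new, unique, unknown or untested is made for them only; others in the source may bear on it.

Two compounds have a number in an assay for inhibition of 15-hydroxyprostaglandin dehydrogenase [NAD(+)] (Homo sapiens), read by fluorescence, with a stated time of 15 min, in the presence of a further agent that is not named here; a higher number here means a weaker inhibitor, a lower number a stronger inhibitor. Compound 1, `CCCC[S+]([O-])c1sc2nc(-c3nccs3)cc(-c3ccc(C(=O)N(C)C)cc3)c2c1N`, gives 5.9 nM in this assay, the lower of the two numbers. Compound 2, `CCCC[S+]([O-])c1cc2c(-c3ccccc3)nc(-c3ccccc3)nc2s1`, which carries a different core, gives 93 nM in this assay, a higher number that lies beyond the usual scatter. Compound 3, `CCCC[S+]([O-])c1sc2nc(-c3nccs3)cc(-c3ccc(CCO)cc3)c2c1N`, has not yet been measured. It differs from compound 1 in one place: 2-hydroxyethyl in place of dimethylcarbamoyl on an aromatic carbon. The change sits on the outer arm of the shared core, while the rest of compound 1 is kept. For the measured compounds named here, with no pair of measured compounds showing the effect of such a swap, there is no direct guide; the expected step of a 1.4-fold higher number from compound 1 to compound 3 (0.13 log units; within the scatter) is small and could fall on either side of the scatter. Compound 3 is therefore estimated at 8 nM in this assay, within 2.5 nM to 30 nM.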

Compound 3, half-maximal inhibitory concentration: 2.9 nM
Compound 3: the middle estimate sits 2.8-fold (0.44 log units) above what was measured; measured number inside the range.
By their numbers in this assay, from the lowest: compound 3; then compound 1; then compound 2.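

In this assay, the outer arm of the shared core does not depend on the dimethylcarbamoyl group: placing 2-hydroxyethyl on this aromatic carbon, para to a large group, gives a 2.0-fold lower number from compound 1 to compound 3 (0.31 log units; beyond the scatter). The amide can therefore be replaced here by a smaller group that carries a hydrogen-bond donor, with the number falling rather than rising, although this rests on a single pair of compounds. Nothing available explains the step.

This single swap does not separate the effect of adding the hydroxyl from that of removing the amide. On these data alone, it also remains open how a longer chain such as 3-hydroxypropyl, a primary amine or a carboxylic acid would fare on the same carbon.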